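The compounds below may be only part of what the source reports. "The series", "measured", "known", "first", "only" and "open" are said of these compounds alone.

Working notes on the series. In a functional assay on DU-145 cells (Homo sapiens) for cytotoxicity, read by MTT assay, with a stated time of 72 h (a higher number here means a weaker inhibitor, a lower number a stronger inhibitor), compound 1 `COc1ccc(C(=O)c2cc(OC)c(OC)c(OC)c2)cc1NC(=O)/C=C/c1cc(OC)c(OC)c(OC)c1` gives 6300 nM. Compound 2 `COc1cccc(/C=C/C(=O)Nc2cc(C(=O)c3cc(OC)c(OC)c(OC)c3)ccc2OC)c1` gives 6200 nM in this assay, and compound 3 `COc1ccc(C(=O)c2cc(OC)c(OC)c(OC)c2)cc1NC(=O)/C=C/c1ccc(F)cc1` gives 3900 nM. Compound 3 stands at the low end of the three numbers, but the steps to it are small: a 1.6-fold lower number from compound 1 to compound 3 (0.21 log units; within the scatter) and a 1.6-fold lower number from compound 2 to compound 3 (0.20 log units; within the scatter), and between the other two a 1.0-fold lower number from compound 1 to compound 2 (0.01 log units; within the scatter). Across these three compounds, changing the aryl group on the ethenyl chain has moved nothing beyond the scatter.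

Compound 4 `COc1ccc(C(=O)c2cc(OC)c(OC)c(OC)c2)cc1NC(=O)/C=C/c1ccc(C(F)(F)F)cc1` is not yet measured. It differs from compound 3 by trifluoromethyl in place of fluoro on an aromatic carbon. This is again a change of the aryl group on the ethenyl chain while the rest of the molecule is kept, so the three measured steps are the relevant comparison. Among the measured compounds shown here, all of them stayed within the scatter, and nothing so far singles out any substituent on this aryl group as mattering. The expectation is therefore no step beyond the scatter in this assay, with no direction favoured; the estimated step is a 1.0-fold higher number from compound 3 to compound 4 (0.01 log units; within the scatter).

For compound 4 the expected value in this assay is 4000 nM, estimated to lie between 1500 nM and 10000 nM.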

Compound 4, half-maximal inhibitory concentration: 4300 nM
Compound 4: the middle estimate sits 1.1-fold (0.03 log units) below what was measured; low and high end bracket the measured number.
By their numbers in this assay, from the lowest: compounds 3, 4, 2 and 1 (each within the scatter of the next).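

In this assay, among the compounds shown here, trifluoromethyl with its four heavy atoms, in place of the single fluorine of compound 3 and para to a large group, leaves the number within the scatter (a 1.1-fold higher number from compound 3 to compound 4 (0.04 log units; within the scatter)). The 4-(trifluoromethyl)phenyl group also stays within the scatter of the 3-methoxyphenyl group (a 1.4-fold lower number from compound 2 to compound 4 (0.16 log units; within the scatter)) and of the 3,4,5-trimethoxyphenyl group (a 1.5-fold lower number from compound 1 to compound 4 (0.17 log units; within the scatter)), so the four aryl groups on the ethenyl chain cannot be told apart in this assay, whether they carry fluoro, trifluoromethyl or one or three methoxy groups. No measured property of these groups is available to bear on this result.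

Still open, on these data alone, is whether a group of another kind on this aromatic ring, such as an amine or a carboxylic acid, would give a step beyond the scatter. Also open is whether a change elsewhere on the shared core would shift the number, as every step among these four compounds lies in the aryl group on the ethenyl chain.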